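The source may report more compounds than this note shows. Statements on the series, on what has been measured and on what is new or still open speak of the compounds shown alone.

Compound 2 `Nc1cccc2c(-c3cccc(NC(=O)c4ccc5c(c4)OCCO5)c3)ccnc12` carries the lowest number of the two compounds measured in a functional assay on MDA-MB-435 cells (Homo sapiens) for antiproliferative activity, read by sulforhodamine B assay, with a stated time of 48 h; on this read-out lower numbers stand for stronger inhibition and higher numbers for weaker inhibition: compound 2 gives 30 nM, while compound 1 `Nc1cccc2c(-c3cccc(NC(=O)c4ccc(Cl)c(C(F)(F)F)c4)c3)ccnc12` gives 2900 nM, a gap far beyond the usual scatter. Compound 3 `Nc1cccc2c(-c3cccc(NC(=O)c4nccs4)c3)ccnc12` is the same as compound 2 except for a single exchange: 1,3-thiazol-2-yl in place of 2,3-dihydro-1,4-benzodioxin-6-yl on a carbonyl carbon. Going by these compounds, the whole size of that change is untested here. Because compound 1 shows with 2900 nM that the group on the carbonyl carbon matters greatly, a step toward weaker inhibition is expected, of size a 10-fold higher number from compound 2 to compound 3 (1.00 log units; beyond the scatter). Compound 3 is thus estimated at 300 nM, somewhere between 40 nM and 2500 nM.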

Compound 3, half-maximal inhibitory concentration: 1700 nM
The estimate for compound 3 lay 5.7-fold (0.75 log units) below the measured number; the range from low to high includes it.
By their numbers in this assay, from the lowest: compound 2; then compounds 3 and 1 (each within the scatter of the next).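

Putting 1,3-thiazol-2-yl on the carbonyl carbon in place of 2,3-dihydro-1,4-benzodioxin-6-yl gives, in this assay, a 57-fold higher number from compound 2 to compound 3 (1.75 log units; beyond the scatter), the first clean measure of what this single exchange does. Compound 3 and compound 1 lie within the scatter of each other, so two very different groups at this position give comparable numbers. No measured evidence explains the size of this step. Still open, going by these compounds, is which part of 2,3-dihydro-1,4-benzodioxin-6-yl matters. A plain phenyl or a 4-methoxyphenyl group at this position would begin to separate the ring oxygens from the two-ring frame.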